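Swapping the Benzyl Substituent in a Sulfonamide Series

This account rests on a few compounds, and the source may have more. Where it says the series, first, only, none or still open, it means among the compounds named here.

Compound 1, `COc1ccc(CNCCCNS(=O)(=O)c2cc(C(F)(F)F)cc(C(F)(F)F)c2)cc1OC` — 2800 nM
Compound 2, `O=S(=O)(NCCCCCCNCc1ccc(Br)cc1)c1c(Cl)cccc1Cl` — 14700 nM

In a functional assay on MIA PaCa-2 cells (Homo sapiens) for inhibition, read by MTT assay, with a stated time of 72 h (a higher number here means a weaker inhibitor of growth, a lower number a stronger inhibitor of growth), compound 1 gives 2800 nM, the lowest of the two numbers. Compound 2 gives 14700 nM in this assay, a gap beyond the scatter; but the two compounds differ in several places at once, so no single step can be read from that pair. Compound 3, `O=S(=O)(NCCCNCc1ccc(Br)cc1)c1cc(C(F)(F)F)cc(C(F)(F)F)c1`, differs from compound 1 in one place only: 4-bromophenyl in place of 3,4-dimethoxyphenyl on a saturated chain carbon bound to an amine nitrogen. Compound 2 carries the same 4-bromophenyl group and stands at the higher number, yet its other differences leave this unexplained, so the change is judged on its own. A modest move toward a higher number is expected for compound 3, near the edge of the scatter: a 1.6-fold higher number from compound 1 to compound 3 (0.21 log units; within the scatter). Compound 3 is estimated at 4500 nM, with a range from 1500 nM to 13000 nM.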

Compound 3, concentration for 50% growth inhibition: 2300 nM
Estimate against measurement, compound 3: 2.0-fold (0.29 log units) above; the range from low to high includes it.
By their numbers in this assay, from the lowest: compounds 3 and 1 (each within the scatter of the next); then compound 2.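

In this assay, replacing 3,4-dimethoxybenzyl with 4-bromobenzyl gives a 1.2-fold lower number from compound 1 to compound 3 (0.09 log units; within the scatter), so at this place, on a saturated chain carbon bound to an amine nitrogen, the assay does not separate the two groups. The two groups differ in make-up, one carrying two oxygens and the other a bromine with no hydrogen-bond acceptors, yet that difference leaves no readable mark on growth inhibition in this pair. No measurement shown here offers an explanation for this result.

On these data alone, it remains open whether a carboxylic acid or a dimethylamino group on the phenyl ring would hold the number at this level or shift it. Compound 2 shares the 4-bromobenzyl group but differs from compound 3 in more than one place, so its steps cannot be read.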